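A few compounds are considered here, and "the series" means these few. Any claim that something is new, unique, unknown or untested is made for them only; others in the source may bear on it.

Measured compounds in a functional assay on A2780 cells (Homo sapiens) for inhibition, read by MTT assay, with a stated time of 72 h; on this read-out higher numbers stand for weaker inhibition of growth and lower numbers for stronger inhibition of growth:
- compound 1 `O=S(=O)(NCCCNCc1ccccc1Cl)c1cc(C(F)(F)F)cc(C(F)(F)F)c1`: compound 1 gives 9300 nM
- compound 2 `COc1ccc(CNCCCNS(=O)(=O)c2cc(C(F)(F)F)cc(C(F)(F)F)c2)cc1OC`: compound 2 gives 3800 nM

Among the compounds with values here, compound 1 stands highest of the two numbers; the only neighbour is compound 2, reached by a 2.4-fold lower number from compound 1 to compound 2 (0.39 log units; beyond the scatter) through 3,4-dimethoxyphenyl in place of 2-chlorophenyl. Compound 3 `COc1ccccc1CNCCCNS(=O)(=O)c1cc(C(F)(F)F)cc(C(F)(F)F)c1` differs from compound 1 by methoxy in place of chloro on an aromatic carbon. Within the data shown here, no measured step covers a single methoxy at this position; the step from compound 1 to compound 2 is the only bearing, and it is modest. The expected step is therefore a 1.6-fold lower number from compound 1 to compound 3 (0.19 log units; within the scatter), toward a lower number but possibly within the scatter. Compound 3 is estimated at 6000 nM, range 2500 nM to 15000 nM.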

Compound 3, concentration for 50% growth inhibition: 1500 nM
Compound 3: the middle estimate sits 4.0-fold (0.60 log units) above what was measured; measured number outside the range, below it.
By their numbers in this assay, from the lowest: compound 3; then compound 2; then compound 1.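

In this assay, methoxy in place of chloro on this aromatic carbon gives a 6.2-fold lower number from compound 1 to compound 3 (0.79 log units; beyond the scatter), so the ring carbon ortho to a large group is sensitive to this change. The 2-methoxyphenyl group also outperforms the 3,4-dimethoxyphenyl group, with a 2.5-fold lower number from compound 2 to compound 3 (0.40 log units; beyond the scatter), so adding methoxy groups does not simply lower the number. No measurement available gives a cause for either step.

Compound 2 and compound 3 differ both in where the methoxy groups sit and in how many there are. The data do not separate these two differences. Ethoxy or fluoro on this carbon remains open, as does a longer chain.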